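Morpholin-4-yl for Diisopropylamino: One Change on Two Cores

The source may report more compounds than this note shows. Statements on the series, on what has been measured and on what is new or still open speak of the compounds shown alone.

All of the compounds here were tested in a functional assay on SW480 cells (Homo sapiens) for antiproliferative activity, read by MTT assay, with a stated time of 72 h; a lower number here means a stronger inhibitor, a higher number a weaker inhibitor. Compound 1, with the structure `COc1ccc2occ(CSC(=S)N(C(C)C)C(C)C)c(=O)c2c1`, gives 4800 nM in this assay. Compound 2, with the structure `COc1ccc2occ(CSC(=S)N3CCOCC3)c(=O)c2c1`, gives 7100 nM in this assay. The two share one core and differ in a single change: morpholin-4-yl in place of diisopropylamino on a thiocarbonyl carbon. The measured step is a 1.5-fold higher number from compound 1 to compound 2 (0.17 log units; within the scatter), so the two values cannot be told apart with confidence.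

Compound 3, with the structure `CC(C)N(C(=S)SCc1cc(=O)c2ccccc2o1)C(C)C`, is built on a different core, and how that core differs from the core of compound 1 is not broken down here. In this assay compound 3 does not give a number but only a limit, > 40000 nM. This is the limit of > 40000 nM in this assay, at which 1 of the 3 values shown sits.

Compound 4, with the structure `O=c1cc(CSC(=S)N2CCOCC2)oc2ccccc12`, has not yet been measured. It stands to compound 3 exactly as compound 2 stands to compound 1, through the same change at the same place: morpholin-4-yl in place of diisopropylamino on a thiocarbonyl carbon.

The expected step is a step that the limit leaves unreadable from compound 3 to compound 4, and this rests on the earlier measured pair, where the step was a 1.5-fold higher number from compound 1 to compound 2 (0.17 log units; within the scatter) and stayed within the scatter. Compound 4 is therefore expected to give 60000 nM, with a likely range from 30000 nM to 150000 nM, and the assay is expected most often to report only a limit for compound 4 rather than a number.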

Compound 4, half-maximal inhibitory concentration: 24400 nM
Estimate against measurement, compound 4: 2.5-fold (0.39 log units) above, and the stated range ends above it.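

Replacing diisopropylamino with morpholin-4-yl on the core of compound 3 gives an at least 1.6-fold lower number from compound 3 to compound 4 (0.21 log units; that floor lies within the scatter) in this assay. On these data alone, compound 3 has only a limit, > 40000 nM, and not a number, so that step is a floor and the true size of the step stays unknown. This shows that the change on this second core can be given only a lower bound, and it does not show whether the change carries over from one core to the other unaltered or acts differently on each: the same change on two cores in this assay, a 1.5-fold higher number (0.17 log units; within the scatter) from compound 1 to compound 2 and an at least 1.6-fold lower number (0.21 log units; that floor lies within the scatter) from compound 3 to compound 4; the limit leaves it open whether they differ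

The compounds shown leave open what size the step on the second core would take if both of its ends were numbers, and so whether the two cores truly answer alike to this change. They also leave open how other amines on the thiocarbonyl carbon, such as piperidin-1-yl or diethylamino, would compare with diisopropylamino and morpholin-4-yl on either core.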